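The source may report more compounds than this note shows. Statements on the series, on what has been measured and on what is new or still open speak of the compounds shown alone.

Measured so far in a functional assay on MCF7 cells (Homo sapiens) for inhibition; on this read-out higher numbers stand for weaker inhibition and lower numbers for stronger inhibition:
Compound 1 `CCCCCC[C@@]1(C)SC(=O)C=C1OC` gives 14 ug/mL.
Compound 2 `CCCCCCCC[C@@]1(C)SC(=O)C=C1OC` gives > 50 ug/mL, which is a limit of the assay and not a number.

For the measured compounds named here, compound 1 holds the only number in this assay; the remaining value is a limit. Compound 3 `C=CCOC1=CC(=O)S[C@]1(C)CCCCCC` differs from compound 1 by vinyl in place of hydrogen on a saturated chain carbon bound to an oxygen on an unsaturated carbon. Going by the values given here, the one measured step, an at least 3.5-fold higher number from compound 1 to compound 2 (0.55 log units; beyond the scatter), alters a different place on the molecule, and the reading for compound 2 sits at a limit (the limit of > 50 ug/mL in this assay, at which 1 of the 2 values shown sits), so it bears only loosely on the present change. The expected step is therefore small: a 1.4-fold higher number from compound 1 to compound 3 (0.15 log units; within the scatter), an estimate. Compound 3 is expected to give 20 ug/mL, within 8 ug/mL to 50 ug/mL.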

Compound 3, half-maximal inhibitory concentration: > 50 ug/mL
Compound 3: only a limit was reported (the forecaster's own chance of this, stated with the estimate: 25%); middle value at least 2.5-fold (0.39 log units) away from the limit.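

In this assay, for the compounds shown here, replacing methoxy with allyloxy gives an at least 3.5-fold higher number from compound 1 to compound 3 (0.55 log units; beyond the scatter), so this position, untouched by the earlier compounds, does not accept the change freely. The change in compound 2 also weakened inhibition, but at a different place, so the shared core now shows a loss at two places. The reading for compound 3 is a limit and not a number, so the true size of the loss stays unknown: the limit of > 50 ug/mL in this assay, at which 2 of the 3 values shown sit.

From the compounds shown here alone, whether the loss comes from the longer group or from its double bond stays open, and propoxy would separate the two. Going by these compounds, it is also open whether an amine in place of methoxy would keep the inhibition of compound 1, which gives 14 ug/mL.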